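Bromo to Methyl on the Benzyl Ring of Compound 3

A few compounds are considered here, and "the series" means these few. Any claim that something is new, unique, unknown or untested is made for them only; others in the source may bear on it.

Compound 1 `O=C(NC1CCN(Cc2ccccc2Cl)CC1)c1cccc2ccccc12`: 329 nM in an assay on isolated protein for displacement of a labelled ligand from D(4) dopamine receptor (Homo sapiens); a lower number here means a stronger inhibitor, a higher number a weaker inhibitor
Compound 2 `Cc1ccc(CN2CCC(NC(=O)c3cccc4ccccc34)CC2)cc1`: 69 nM in this assay
Compound 3 `O=C(NC1CCN(Cc2cccc(Br)c2)CC1)c1ccc2ccccc2c1`: 36 nM in this assay

Compound 3 has the lowest of the three numbers, though compound 2 lies within the usual scatter of it; only compound 1 stands clearly higher. Compound 4 `Cc1cccc(CN2CCC(NC(=O)c3ccc4ccccc4c3)CC2)c1` differs from compound 3 by methyl in place of bromo on an aromatic carbon. Among the compounds with values here, the one measured step that touches a similar swap, a halogen giving way to a methyl on the benzyl ring, is a 4.8-fold lower number from compound 1 to compound 2 (0.68 log units; beyond the scatter); there, however, a 4-methylphenyl replaced a 2-chlorophenyl, and the change was modest. For compound 4 the expected step is therefore small, a 1.1-fold higher number from compound 3 to compound 4 (0.05 log units; within the scatter), likely nothing beyond the scatter. Compound 4 is estimated at 40 nM, within 15 nM to 110 nM.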

Compound 4, inhibition constant: 11 nM
Compound 4: the middle estimate sits 3.6-fold (0.56 log units) above what was measured; measured number outside the range, below it.
By their numbers in this assay, from the lowest: compound 4; then compounds 3 and 2 (each within the scatter of the next); then compound 1.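

Putting methyl in place of bromo, with nothing else altered, gives a 3.3-fold lower number from compound 3 to compound 4 (0.51 log units; beyond the scatter) in this assay, so the group at this spot on the benzyl ring affects the number even though each group has one heavy atom. The earlier step from 2-chlorophenyl to 4-methylphenyl changed the group's place as well as the group, so it could not show this for one fixed place. Nothing available here explains why methyl gives the lower number. On these data alone, it remains open how an ethyl, a methoxy or an amine would fare at this place, and whether the same swap would act alike with the amide part of compound 2.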